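The compounds below may be only part of what the source reports. "The series", "measured", "known", "first", "only" and "open" are said of these compounds alone.

Measured compounds:
Compound 1 `NC(=O)c1c(NC(=O)c2ccccc2Cl)sc2c1CCN(Cc1ccccc1Cl)C2` gives 27500 nM in a functional assay on HeLa cells (Homo sapiens) for antiproliferative activity, with a stated time of 24 h; on this read-out lower numbers stand for stronger inhibition and higher numbers for weaker inhibition.
Compound 2 `NC(=O)c1c(NC(=O)c2ccccc2Cl)sc2c1CCN(C(=S)Nc1ccccc1)C2` gives 46700 nM in this assay.
Compound 3 `NC(=O)c1c(NC(=O)c2ccccc2Cl)sc2c1CCN(C(=O)Nc1ccccc1Cl)C2` gives 45400 nM in this assay.

Compound 3 stands second highest of the three numbers. Its nearest neighbour is compound 2, with a 1.0-fold lower number from compound 2 to compound 3 (0.01 log units; within the scatter), and its furthest is compound 1, with a 1.7-fold higher number from compound 1 to compound 3 (0.22 log units; within the scatter); both gaps fall within the scatter, so the three compounds cannot be separated on these numbers.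

Compound 4 `NC(=O)c1c(NC(=O)c2ccccc2Cl)sc2c1CCN(C(=O)Nc1c(Cl)cccc1Cl)C2` is the unmeasured compound. It differs from compound 3 by chloro in place of hydrogen on an aromatic carbon, on an aromatic carbon ortho to a large group and meta to a chloro group; cut one bond further out, the change reads (2-chlorophenyl)carbamoyl to (2,6-dichlorophenyl)carbamoyl.

Among the compounds with values here, no measured step exchanges a hydrogen for a chloro on this ring, so nothing bears directly on the change. The steps that exist, a 1.7-fold higher number from compound 1 to compound 2 (0.23 log units; within the scatter) and a 1.7-fold higher number from compound 1 to compound 3 (0.22 log units; within the scatter), show that larger exchanges at the same ring nitrogen stayed within the scatter. On that basis the step of a 1.1-fold lower number from compound 3 to compound 4 (0.03 log units; within the scatter) is expected to stay within the scatter, with no clear direction. Compound 4 is therefore estimated at 42000 nM, with a range from 15000 nM to 120000 nM.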

Compound 4, half-maximal inhibitory concentration: 27200 nM
Estimate against measurement, compound 4: 1.5-fold (0.19 log units) above; low and high end bracket the measured number.
By their numbers in this assay, from the lowest: compounds 4, 1, 3 and 2 (each within the scatter of the next).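

In this assay, within the data shown here, chloro in place of hydrogen on an aromatic carbon gives a 1.7-fold lower number from compound 3 to compound 4 (0.22 log units; within the scatter), the first direct reading of this change, and it stays within the scatter. The exchanges at the ring nitrogen read alike, with a 1.7-fold lower number from compound 2 to compound 4 (0.23 log units; within the scatter) and a 1.0-fold lower number from compound 1 to compound 4 (0.00 log units; within the scatter), so the (2,6-dichlorophenyl)carbamoyl group does not set compound 4 apart from the other three compounds. No measurement is available that would account for these readings.

Going by these compounds, whether another group on this aromatic carbon, such as methoxy or an amine, would give a step beyond the scatter remains open. All four compounds also share the rest of the core, so the effect of a change there, such as a carboxylic acid in place of the primary amide, is open too.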